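Trading Hydroxy for Anilino on a Carbonyl Carbon

The source may hold more compounds than are shown below. What is called first, only, known or untested is meant among the compounds shown, and "the series" means these compounds.

Of the compounds shown here, three have been measured so far in a functional assay on NCI-H460 cells (Homo sapiens) for inhibition, read by MTT assay, with a stated time of 24 h, tested at 100 ug/mL; a higher number here means more inhibition of growth at the concentration tested, a lower number less inhibition of growth. Compound 1 `CC(=O)SCCC(CCCCC(=O)O)SC(C)=O` gives 11%, the lowest of the three. Compound 3 `COc1ccc(NC(=O)CCCCC(S)CCS)cc1` gives 23.5%, and compound 2 `O=C(CCCCC1CCSS1)Nc1ccc([N+](=O)[O-])c(C(F)(F)F)c1` gives 51.7%. Both of these numbers lie beyond the usual scatter of repeated measurements when set against compound 1.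

The next compound to be tested, compound 4 `CC(=O)SCCC(CCCCC(=O)Nc1ccccc1)SC(C)=O`, matches compound 1 except at a single place. It has anilino in place of hydroxy on a carbonyl carbon.

Within the data shown here, no measured pair of compounds isolates this one change, so its effect in this assay can only be judged indirectly. Compound 3 and compound 2 also have no hydroxy on that carbonyl carbon and carry a six-membered aromatic ring of carbon only, but they differ from compound 1 in other places too. Their numbers therefore offer only a rough guide. With compound 3 at 23.5% and compound 2 at 51.7%, an upward move seems more likely than none. The expected change is an estimated a number 19 percentage points higher from compound 1 to compound 4 (beyond the scatter). Compound 4 is expected to give about 30%, within an estimated range of 15% to 50%.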

Compound 4, percent growth inhibition at one concentration: 44.8%
Compound 4: the middle estimate sits 14.8 percentage points below what was measured; measured number inside the range.
By their numbers in this assay, from the lowest: compound 1; then compound 3; then compounds 4 and 2 (each within the scatter of the next).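

Replacing hydroxy with anilino on a carbonyl carbon gives a number 33.8 percentage points higher from compound 1 to compound 4 (beyond the scatter) in this assay, and nothing else differs between the two structures. Among these compounds, this is the first direct reading of this change. The earlier compounds shown here could only hint at it, and each of them differs from compound 1 in more than one place. It shows that this position is not silent: what sits on the carbonyl carbon can shift growth inhibition well past normal measurement noise, even with the rest of the core of compound 1 left untouched.

A single step cannot separate the contribution of the aromatic ring from that of replacing hydroxy with a nitrogen-linked group, and a methylamino group on the same carbonyl carbon, which has no ring, would pull these two apart. The compounds shown also leave open whether a benzylamino group, with a longer link to its ring, or a chloro group on the anilino ring would raise or lower the number.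

No supporting measurement is available to explain the size of this rise.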